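Step from compound 3 to compound 4: methoxy to hydrogen

The source may report more compounds than this note shows. Statements on the series, on what has been measured and on what is new or still open speak of the compounds shown alone.

Measured in a functional assay, read by spectrophotometry, with a stated time of 15 min, tested at 80 ug/mL; on this read-out lower numbers stand for a weaker effect and higher numbers for a stronger effect at the one concentration tested:
compound 1 `Fc1ccc(-c2csc(N/N=C/c3ccc(Cl)cc3Cl)n2)cc1`: 95.5%
compound 2 `COC(=O)c1cc(-c2csc(N/N=C/c3ccc(Cl)cc3Cl)n2)ccc1OCc1ccccc1`: 45.5%
compound 3 `COc1ccc(-c2csc(N/N=C/c3ccc(Cl)cc3Cl)n2)cc1`: 90.6%

Compound 3 stands second highest of the three numbers. Its nearest neighbour is compound 1, and the step of a number 4.9 percentage points lower from compound 1 to compound 3 (within the scatter) lies within the scatter. Compound 2 lies furthest away, its value beyond the scatter below that of compound 3.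

Compound 4 `Clc1ccc(/C=N/Nc2nc(-c3ccccc3)cs2)c(Cl)c1` differs from compound 3 by hydrogen in place of methoxy on an aromatic carbon. For the measured compounds named here, the only measured step that bears on this change is the exchange of one group for another on the same aromatic carbon, a number 4.9 percentage points lower from compound 1 to compound 3 (within the scatter), which was within the scatter. Going by the values given here, no step removing a group entirely has been measured. On this basis no step beyond the scatter is expected in this assay, and the step from compound 3 to compound 4 is estimated at a number 4.6 percentage points lower from compound 3 to compound 4 (within the scatter). Compound 4 is therefore expected to give about 86%, in the range 70% to 97%.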

Compound 4, a percentage reported as inhibition, at one concentration (the size of the read-out at that concentration, not a potency): 92.6%
Beside the measured number, compound 4's estimate is 6.6 percentage points below it, within the range that was stated.
By their numbers in this assay, from the lowest: compound 2; then compounds 3, 4 and 1 (each within the scatter of the next).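

In this assay, removing the methoxy leaves the read-out within the scatter (a number 2 percentage points higher from compound 3 to compound 4 (within the scatter)), so this place does not need a substituent to hold the number. The unsubstituted phenyl also matches the fluoro compound (a number 2.9 percentage points lower from compound 1 to compound 4 (within the scatter)), and hydrogen, fluoro and methoxy, para to a large group, cannot be told apart here. No evidence bears on this result.

Open, as far as these compounds go, is whether an amine, a carboxylic acid or a longer alkoxy chain at this place would stay level with these compounds. The single concentration also leaves their potencies unresolved.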